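The compounds below may be only part of what the source reports. "The series", "measured", "known", "first", "only" and "open" are said of these compounds alone.

Measured so far in a functional assay on MT2 cells (Homo sapiens) for cytotoxicity, read by MTT assay; a lower number here means that less compound is tolerated, a higher number that more compound is tolerated:
- compound 1 `COc1ccc(Nc2nccs2)cc1OCC=C(C)C`: 42000 nM
- compound 2 `CC(C)=CCOc1cc(Nc2nccs2)ccc1C(=O)O`: 17000 nM
- compound 3 `N#Cc1ccc(Nc2nccs2)cc1OCc1ccco1`: 18000 nM

The number for compound 3 lies within the scatter of that for compound 2, and the number for compound 1 is higher than both. Compound 4 `N#Cc1ccc(Nc2nccs2)cc1OCc1ccsc1` differs from compound 3 by one exchange: thiophen-3-yl in place of furan-2-yl on a saturated chain carbon bound to an oxygen on an aromatic ring. Among the measured compounds shown here, only one measured step is available, a 2.5-fold lower number from compound 1 to compound 2 (0.39 log units; beyond the scatter), a modest one with carboxy in place of methoxy on an aromatic carbon. For the measured compounds named here, it involves a different exchange, and no measured step involves these two rings, so it bears only weakly on this change. No shift beyond the scatter is therefore expected in this assay. The expected step is a 1.1-fold lower number from compound 3 to compound 4 (0.05 log units; within the scatter). Compound 4 is estimated at 16000 nM, with an expected range of 7000 nM to 36000 nM.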

Compound 4, half-maximal cytotoxic concentration: 1100 nM
For compound 4 the middle estimate is 15-fold (1.16 log units) above the measured one; the measured number lies below the stated range.
By their numbers in this assay, from the lowest: compound 4; then compounds 2 and 3 (each within the scatter of the next); then compound 1.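

In this assay, the ring on a saturated chain carbon bound to an oxygen on an aromatic ring proves to matter: thiophen-3-yl in place of furan-2-yl gives a 16-fold lower number from compound 3 to compound 4 (1.21 log units; beyond the scatter). The two groups match in heavy-atom count, ring size and counted donors and acceptors, so a large step can accompany an exchange that leaves these counts unchanged. Nothing measured here accounts for the step.

The compounds shown leave open whether the sulfur or the point of attachment goes with this step, which thiophen-2-yl or furan-3-yl at this place would separate. Also open, from the compounds shown here alone, is how a phenyl ring there would compare.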